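Branching at the nitrogen-bound carbon: cyanoguanidine series notes

The source may hold more compounds than are shown below. What is called first, only, known or untested is meant among the compounds shown, and "the series" means these compounds.

Measured so far:
compound 1, `C/N=C(\NC#N)Nc1cccnc1`, a limit of the assay: > 50 mg/kg
compound 2, `CCC(CC)/N=C(\NC#N)Nc1cccnc1`: 20 mg/kg
compound 3, `CCC(C)(CC)/N=C(\NC#N)Nc1cccnc1`: 0.5 mg/kg

In a functional assay on the whole organism (blood, strain Wistar-Okamoto) with Rattus norvegicus as the target, with a stated time of 5 days (a lower number here means that less compound is needed, a higher number that more compound is needed for the effect), compound 1 gives only a limit, > 50 mg/kg, as recorded under (the limit of > 50 mg/kg in this assay, at which 1 of the 3 values shown sits). Compound 2 gives 20 mg/kg, and compound 3 gives 0.5 mg/kg, the lowest number among the two numbers shown. The step separating it from its nearest neighbour is a 40-fold lower number from compound 2 to compound 3 (1.60 log units; beyond the scatter), a large one, and against compound 1 the steps are an at least 2.5-fold lower number from compound 1 to compound 2 (0.39 log units; beyond the scatter) and an at least 100-fold lower number from compound 1 to compound 3 (2.00 log units; beyond the scatter).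

Compound 4 is `CCC(CC)(CC)/N=C(\NC#N)Nc1cccnc1`. The change from compound 3 is methyl in place of hydrogen on a saturated chain carbon, two bonds along the chain from a double-bonded nitrogen. Of the measured steps, a 40-fold lower number from compound 2 to compound 3 (1.60 log units; beyond the scatter) bears most directly, but that step created the fully substituted carbon; the present change only lengthens one arm already on it, and the same difference read one bond further out is methyl to ethyl. The step of an at least 2.5-fold lower number from compound 1 to compound 2 (0.39 log units; beyond the scatter) shows that enlarging the alkyl group alone gave a smaller effect than adding the branch. For compound 4 a step within the scatter is therefore expected, no change at the digits printed from compound 3 to compound 4 (within the scatter). Compound 4 is estimated at 0.5 mg/kg, with a range from 0.1 mg/kg to 2.5 mg/kg.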

Compound 4, minimum effective dose: 1 mg/kg
The estimate for compound 4 lay 2.0-fold (0.30 log units) below the measured number; the measured number falls inside the stated range.
By their numbers in this assay, from the lowest: compounds 3 and 4 (each within the scatter of the next); then compound 2. At a limit, above all of these: compound 1.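

In this assay, methyl in place of hydrogen on a saturated chain carbon, two bonds along the chain from a double-bonded nitrogen, gives a 2.0-fold higher number from compound 3 to compound 4 (0.30 log units; within the scatter), so this position accepts the methyl to ethyl difference without a change that can be told from the scatter. The large gain on filling the carbon bound to the double-bonded nitrogen is also not tied to methyl: ethyl there gives a 20-fold lower number from compound 2 to compound 4 (1.30 log units; beyond the scatter), which stands beside a 40-fold lower number from compound 2 to compound 3 (1.60 log units; beyond the scatter) as a second large step in the same direction, and the series now has two compounds with a fully substituted carbon, both well apart from compound 2. No measurement shown gives a reason for either the gain at that carbon or the tolerance one bond further out.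

The compounds shown leave open how far the arms on the fully substituted carbon can grow, for instance to a longer chain such as butyl, or whether they can be closed into a cyclohexyl ring. They also leave open whether an arm carrying a hydroxyl or an amine would keep the low dose of compound 3 and compound 4.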